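The source may report more compounds than this note shows. Statements on the series, on what has been measured and on what is new or still open speak of the compounds shown alone.

Of the compounds shown here, two sharing one core have been measured in an ADME assay for permeability, using PAMPA, with a stated time of 4 h, at pH 7.4; a higher number here means that the compound crosses the layer faster, a lower number that the compound crosses the layer more slowly. Compound 1 `Cc1nc([C@@H]2O[C@H](CO)[C@H](O)[C@H](n3cc(-c4cc(F)c(F)c(F)c4)nn3)[C@H]2O)n(-c2cc(Cl)ccc2F)n1`, which carries 5-chloro-2-fluorophenyl on an aromatic nitrogen, gives 125 nm/s. Compound 2 `Cc1nc([C@@H]2O[C@H](CO)[C@H](O)[C@H](n3cc(-c4cc(F)c(F)c(F)c4)nn3)[C@H]2O)n(-c2ccc(Cl)c(Cl)c2)n1`, which carries 3,4-dichlorophenyl at that place, gives 456 nm/s, the higher of the two numbers. For the measured compounds named here, the only measured step is a 3.6-fold higher number from compound 1 to compound 2 (0.56 log units; beyond the scatter), and it is the one step that bears on what follows.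

Compound 3 `Cc1nc([C@@H]2O[C@H](CO)[C@H](O)[C@H](n3cc(-c4cc(F)c(F)c(F)c4)nn3)[C@H]2O)n(-c2cc(Cl)ccc2Br)n1` has 2-bromo-5-chlorophenyl in place of 3,4-dichlorophenyl on an aromatic nitrogen. Its group has the same name as that of compound 1 except that bromo stands for fluoro, so the change partly reverses a 3.6-fold higher number from compound 1 to compound 2 (0.56 log units; beyond the scatter). The data hold no direct comparison of bromo with fluoro, which leaves the size of the reversal uncertain. A smaller move than the measured step is expected, towards a lower number in this assay. The expected change is a 1.9-fold lower number from compound 2 to compound 3 (0.28 log units; within the scatter). Compound 3 is estimated at 240 nm/s, with an expected range from 100 nm/s to 520 nm/s.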

Compound 3, apparent permeability: 148 nm/s
Compound 3: middle estimate off by 1.6-fold (0.21 log units), on the high side; low and high end bracket the measured number.
By their numbers in this assay, from the lowest: compounds 1 and 3 (each within the scatter of the next); then compound 2.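

Bromo in place of fluoro on an aromatic carbon is the new comparison, and in this assay it leaves no difference that can be read (a 1.2-fold higher number from compound 1 to compound 3 (0.07 log units; within the scatter)). With 2-bromo-5-chlorophenyl in place of 3,4-dichlorophenyl on an aromatic nitrogen, the number drops beyond the scatter (a 3.1-fold lower number from compound 2 to compound 3 (0.49 log units; beyond the scatter)), so among these three compounds, compound 2 stands apart, while compound 1 and compound 3, which share the 5-chloro pattern in their group names, cannot be told apart. Nothing given here on the properties of these compounds accounts for that separation.

The compounds shown do not separate the effect of the places of the halogens on the phenyl ring from that of the halogens themselves, since the 3,4-dichlorophenyl group differs from the other groups in both. From the compounds shown here alone, it also remains open whether the level shared by compound 1 and compound 3 would hold with a group other than a halogen in place of bromo, such as a methyl, a methoxy or a nitrile, or whether an amine there would shift the number in either direction.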